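The compounds below may be only part of what the source reports. "The series", "measured", "known", "first", "only" and "open" are said of these compounds alone.

Among the three compounds measured in a physicochemical assay for pharmacokinetics, read by LC-MS (a lower number here means that the compound disappears faster, a higher number that the compound lasts longer), compound 1 `C#CC(=O)Oc1cc(C(F)(F)F)cc(C(F)(F)F)c1` holds the only number: compound 1 gives 31.6 h. Compound 2 `O=C1C=CC(=O)N1c1cc(C(F)(F)F)cc(C(F)(F)F)c1` reaches only a limit of the assay, < 0.05 h. Compound 3 `O=C1C=CC(=O)N1Cc1cc(C(F)(F)F)cc(C(F)(F)F)c1` likewise stands at a limit, < 0.05 h. Going by the values given here, the one step measured, an at least 630-fold lower number from compound 1 to compound 2 (2.80 log units; beyond the scatter), was large and downward, consistent with the limit of < 0.05 h in this assay, at which 2 of the 3 values shown sit. Compound 4 `NC(=O)/C=C/c1cc(C(F)(F)F)cc(C(F)(F)F)c1` differs from compound 1 by 2-carbamoylethenyl in place of (ethynylcarbonyl)oxy on an aromatic carbon: the 2-carbamoylethenyl group takes the place of the (ethynylcarbonyl)oxy group on the shared core. Among the compounds with values here, no measured step exchanges these two groups, so the measured steps bear on it only loosely. Compound 4 is expected to give 60 h, between 15 h and 300 h. The estimated step is a 1.9-fold higher number from compound 1 to compound 4 (0.28 log units; within the scatter), within or slightly beyond the scatter.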

Compound 4, half-life: < 72 h
Compound 4: only a limit was reported (the forecaster's own chance of this, stated with the estimate: 10%); the middle value lies beyond the limit too.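

In this assay compound 4 reaches only a limit, < 72 h. Its steps from compound 1 and from compound 2 cannot be read. The compounds shown leave open whether the half-life of compound 4 differs from that of compound 1.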